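The compounds below may be only part of what the source reports. "The series", "measured", "known", "first", "only" and "open" are said of these compounds alone.

Three measured compounds share one core and differ in the substituted aryl group on the urea nitrogen and in the aryloxy group: compound 1 `O=C(Nc1ccc(I)cc1)N[C@H]1CC[C@H](Oc2ccc(F)cc2)CC1`, compound 2 `COc1cccc(NC(=O)N[C@H]2CC[C@H](Oc3ccc(F)cc3)CC2)c1` and compound 3 `O=C(Nc1cccc(C(F)(F)F)c1)N[C@H]1CC[C@H](Oc2ccccc2C(F)(F)F)CC1`. In a functional assay on CRL2813 cells (Homo sapiens) for cytotoxicity, read by sulforhodamine B assay, with a stated time of 5 days (a higher number here means a weaker inhibitor, a lower number a stronger inhibitor), compound 1 gives 10200 nM, compound 2 gives 14000 nM and compound 3 gives 1400 nM. Compound 2 thus carries the highest of the three numbers; against compound 1 the gap is a 1.4-fold higher number from compound 1 to compound 2 (0.14 log units; within the scatter), while the number for compound 3 lies well apart from it, beyond the scatter.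

Compound 4 `O=C(Nc1cccc(I)c1)N[C@H]1CC[C@H](Oc2ccc(F)cc2)CC1` is not yet measured. Against compound 2 the change is iodo in place of methoxy on an aromatic carbon. Going by the values given here, the one measured step that bears on this change is the exchange of an iodo-bearing for a methoxy-bearing aryl group, a 1.4-fold higher number from compound 1 to compound 2 (0.14 log units; within the scatter), which stayed within the scatter. Putting iodo back, now on the carbon meta to the large group, is therefore expected to move the number only slightly, if at all, toward the lower value of compound 1, so no step beyond the scatter is expected for a 1.4-fold lower number from compound 2 to compound 4 (0.15 log units; within the scatter). For compound 4 in this assay the estimate is 10000 nM, with a range from 4500 nM to 22000 nM.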

Compound 4, half-maximal inhibitory concentration: 5200 nM
Beside the measured number, compound 4's estimate is 1.9-fold (0.28 log units) above it; low and high end bracket the measured number.
By their numbers in this assay, from the lowest: compound 3; then compounds 4, 1 and 2 (each within the scatter of the next, the first and the last beyond it).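

At the 3-methoxyphenyl position, iodo in place of methoxy on an aromatic carbon, meta to a large group, is the one change among these single-place steps that clears the scatter in this assay, with a 2.7-fold lower number from compound 2 to compound 4 (0.43 log units; beyond the scatter), although the step is modest. This shows that the group on this carbon can shift the number, which the earlier comparison of compound 1 and compound 2 could not show, since that step changed both the group and its place and stayed within the scatter. Moving iodo alone, 3-iodophenyl in place of 4-iodophenyl, gives a 2.0-fold lower number from compound 1 to compound 4 (0.29 log units; within the scatter), which is also within the scatter, so these compounds do not establish a preference between the two iodo placements.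

Going by these compounds alone, whether an amine, a carboxylic acid or a nitrile on the same carbon would give a number nearer that of compound 4 or that of compound 2 remains open, as does whether the iodo-for-methoxy step would hold with the aryloxy group of compound 3 in place of the one in compound 2. No data at hand account for the iodo-for-methoxy step.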